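Series notes: cytotoxicity of nitroimidazooxazine analogues

The source may report more compounds than this note shows. Statements on the series, on what has been measured and on what is new or still open speak of the compounds shown alone.

Measured compounds:
- compound 1 `C[C@]1(CN2CCc3nc(-c4ccc(OC(F)(F)F)cc4)ccc3C2)Cn2cc([N+](=O)[O-])nc2O1` — "not determined" (no result reported)
- compound 2 `C[C@]1(CN2CCc3nc(-c4ccc(F)c(F)c4)oc3C2)Cn2cc([N+](=O)[O-])nc2O1` — > 32 ug/mL

Compound 1 `C[C@]1(CN2CCc3nc(-c4ccc(OC(F)(F)F)cc4)ccc3C2)Cn2cc([N+](=O)[O-])nc2O1` has no number in an ADME assay on Vero cells (Chlorocebus sabaeus) for cytotoxicity, read by MTT assay, with a stated time of 72 h; a higher number here means that more compound is tolerated, a lower number that less compound is tolerated; its entry reads "not determined" (no result reported). For compound 2 `C[C@]1(CN2CCc3nc(-c4ccc(F)c(F)c4)oc3C2)Cn2cc([N+](=O)[O-])nc2O1` this assay gives only a limit, > 32 ug/mL, which is the point (the limit of > 32 ug/mL in this assay, at which 1 of the 2 values shown sits).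

Compound 3 `C[C@]1(CN2CCc3nc(-c4ccc(C(F)(F)F)cc4)ccc3C2)Cn2cc([N+](=O)[O-])nc2O1` differs from compound 1 by trifluoromethyl in place of trifluoromethoxy on an aromatic carbon. For the measured compounds named here, with no measured step between any two compounds here, no shift beyond the usual scatter is expected in this assay from this change.

Compound 3 is therefore expected to sit near 32 ug/mL, within 16 ug/mL to 64 ug/mL, and most likely to be reported only as a limit.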

Compound 3, half-maximal cytotoxic concentration: > 32 ug/mL
Compound 3 was reported as a limit (the forecaster's own chance of this, stated with the estimate: 70%); the middle value sits exactly at the limit.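

For the compounds shown here, no step from compound 1 to compound 3 can be read in this assay; compound 3 gives only a limit, > 32 ug/mL. Still open are the actual tolerated concentrations of compound 2 and compound 3, and any difference between trifluoromethoxy and trifluoromethyl: the limit of > 32 ug/mL in this assay, at which 2 of the 3 values shown sit.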